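This account rests on a few compounds, and the source may have more. Where it says the series, first, only, none or still open, it means among the compounds named here.

Measured compounds:
- compound 1, `Cc1ccc(-c2cc(C(=O)NNc3ccc4ccccc4n3)n(Cc3ccccc3)n2)cc1`: 24.1%
- compound 2, `Cc1ccc(-c2cc(C(=O)Oc3ccc(C(C)(C)C)cc3)n(Cc3ccccc3)n2)cc1`: 35%

Of the compounds shown here, two on a shared core have been tested in a functional assay on the whole organism (strain Swiss albino) for inhibition, with Mus musculus as the target, read by paw edema, with stated times of 30 min and 180 min, at a dose of 100 mg/kg by the subcutaneous route; a higher number here means more inhibition at the dose given (going by the name of the read-out), a lower number less inhibition. Compound 2 gives the higher of the two numbers, 35%, and compound 1, at 24.1%, stands lower by a gap that is beyond the usual scatter. Among the compounds with values here, the two differ in more than one place, so no single-change step between measured compounds is available; the pair only shows that the ester of compound 2 sits above the hydrazide of compound 1 in this assay.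

Compound 3, `Cc1ccc(-c2cc(C(=O)Oc3ccc(Oc4ccc(C(F)(F)F)cc4)cc3)n(Cc3ccccc3)n2)cc1`, keeps the ester of compound 2 and changes one place: 4-(trifluoromethyl)phenoxy in place of tert-butyl on an aromatic carbon. Within the data shown here, with no measured step of this kind to lean on, the size of the step from compound 2 to compound 3 in this assay is uncertain; a small shift, most likely toward somewhat more inhibition or none beyond the scatter, is expected. On that basis compound 3 is estimated at 40%, within 25% to 55%, which implies an expected step of a number 5 percentage points higher from compound 2 to compound 3 (within the scatter).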

Compound 3, a percentage reported as inhibition, in the whole organism at one dose (the size of the read-out at that dose, not a potency): 17%
The estimate for compound 3 lay 23 percentage points above the measured number; measured number below the stated range.
By their numbers in this assay, from the lowest: compounds 3 and 1 (each within the scatter of the next); then compound 2.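

In this assay, within the data shown here, 4-(trifluoromethyl)phenoxy in place of tert-butyl on an aromatic carbon of the ester gives a number 18 percentage points lower from compound 2 to compound 3 (beyond the scatter), the first single-change step. This shows that the read-out responds to what sits at this place on the six-membered aromatic ring, so the ester alone does not fix the level of inhibition at the dose given. The change replaces 4 heavy atoms without a ring by 11 heavy atoms with one six-membered aromatic ring and 1 hydrogen-bond acceptor, and no available measurement indicates which of these differences accounts for the step.

The step changes the ring, the oxygen link and the trifluoromethyl group together, so it cannot assign the loss to any one of them; a plain phenoxy, a methoxy or a single chlorine at this place would begin to separate these parts. Also open, on these data alone, is whether a carboxylic acid or an amine at this place would hold the read-out of compound 2, since a single step gives no trend for this position.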